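Swapping the Aryl Group on a Shared Core

The compounds below may be only part of what the source reports. "The series", "measured", "known", "first", "only" and "open" are said of these compounds alone.

Three compounds share one core and differ only in the aryl group on a double-bonded chain carbon bound to a double-bonded chain carbon. Compound 1 `O=C(/C=C\c1ccccc1[N+](=O)[O-])N1N=C(c2ccncc2)OC1c1c[nH]c2ccccc12` carries a 2-nitrophenyl there, compound 2 `COc1ccc(/C=C\C(=O)N2N=C(c3ccncc3)OC2c2c[nH]c3ccccc23)cc1` a 4-methoxyphenyl, and compound 3 `O=C(/C=C\c1ccc(Cl)cc1Cl)N1N=C(c2ccncc2)OC1c1c[nH]c2ccccc12` a 2,4-dichlorophenyl. In an ADME assay on PANC-1 cells (Homo sapiens) for cytotoxicity, read by MTT assay, with a stated time of 48 h (on this read-out lower numbers stand for stronger inhibition of growth and higher numbers for weaker inhibition of growth), compound 1 reaches only a limit, > 30 ug/mL. Compound 2 likewise stops at a limit, > 30 ug/mL. Compound 3 also gives no number but a limit, > 30 ug/mL. The steps a step that the two limits leave unreadable from compound 1 to compound 2, a step that the two limits leave unreadable from compound 1 to compound 3 and a step that the two limits leave unreadable from compound 2 to compound 3 cannot be sized because of the limit of > 30 ug/mL in this assay, at which 3 of the 3 values shown sit. Compound 4 `O=C(/C=C\c1ccc(Br)cc1)N1N=C(c2ccncc2)OC1c1c[nH]c2ccccc12` makes one further change of the same kind: 4-bromophenyl in place of 2,4-dichlorophenyl on a double-bonded chain carbon bound to a double-bonded chain carbon. Since every measured step is hidden by the limit, no direction can be read from them, and compound 4 is expected to sit at or beyond the same limit. The step expected here, a step that the limit leaves unreadable from compound 3 to compound 4, should stay within the scatter. Compound 4 is estimated at 45 ug/mL, with a range from 20 ug/mL to 120 ug/mL.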

Compound 4, concentration for 50% growth inhibition: > 30 ug/mL
Compound 4: a limit, no number (the forecaster's own chance of this, stated with the estimate: 80%); the middle value is on the limit's open side.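

Compound 4 also gives a limit rather than a number, so none of its steps from compound 1, compound 2 or compound 3 can be read, because all four compounds stop at the same point: the limit of > 30 ug/mL in this assay, at which 4 of the 4 values shown sit.

The compounds shown leave open how these four aryl groups would rank in this assay.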